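The source may report more compounds than this note shows. Statements on the series, on what has been measured and on what is new or still open speak of the compounds shown alone.

Measured so far:
compound 1 `O=C(NO)c1ccc(/C=C/c2ccnc(-c3cc(F)ccc3O)c2)cc1`: 130 nM
compound 2 `Cc1ccc(-c2cncc(/C=C/c3ccc(C(=O)NO)cc3)c2)c(F)c1`: 150 nM

In an assay on isolated protein for inhibition of protein deacetylase HDAC6 (Homo sapiens), read by fluorescence, with a stated time of 15 min (on this read-out higher numbers stand for weaker inhibition and lower numbers for stronger inhibition), compound 1 gives 130 nM and compound 2 gives 150 nM; the two numbers lie within the usual scatter of each other, so compound 2 stands level with compound 1 and no order can be read. Compound 3 `O=C(NO)c1ccc(/C=C/c2cncc(-c3ccccc3O)c2)cc1` differs from compound 2 by 2-hydroxyphenyl in place of 2-fluoro-4-methylphenyl on an aromatic carbon. For the measured compounds named here, no step between measured compounds sizes this change. Compound 1 carries a hydroxyphenyl on the shared core, and its number is level with compound 2, so no step beyond the scatter is expected in this assay. The expected step is a 1.2-fold lower number from compound 2 to compound 3 (0.06 log units; within the scatter). Compound 3 is estimated at 130 nM, between 50 nM and 350 nM.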

Compound 3, half-maximal inhibitory concentration: 13 nM
For compound 3 the middle estimate is 10-fold (1.00 log units) above the measured one; measured number below the stated range.
By their numbers in this assay, from the lowest: compound 3; then compounds 1 and 2 (each within the scatter of the next).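

For the compounds shown here, replacing 2-fluoro-4-methylphenyl with 2-hydroxyphenyl on this aromatic carbon, two atoms from the ring nitrogen, gives a 12-fold lower number from compound 2 to compound 3 (1.06 log units; beyond the scatter) in this assay and provides the first step beyond the scatter. Going by these compounds alone, the outcome at this position thus depends strongly on the attached aryl group, which the level values of the earlier compounds did not show. No measurement shown accounts for this step. The change swaps hydroxyl for fluorine and methyl together, leaving open which of these carries the step. As far as these compounds go, the outcome with 2-methoxyphenyl or 2-aminophenyl on the same carbon also remains open.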